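Dichlorophenyl to Bromofluorophenyl: Expected Cytotoxicity Shift

A few compounds are considered here, and "the series" means these few. Any claim that something is new, unique, unknown or untested is made for them only; others in the source may bear on it.

Measured in a functional assay on HL-60 cells (Homo sapiens) for cytotoxicity, read by CCK-8 assay, with a stated time of 72 h; a lower number here means a stronger inhibitor, a higher number a weaker inhibitor:
- compound 1, `C=CCn1c(=O)/c(=C\c2cccc(Cl)c2)[nH]c(=O)/c1=C\c1ccccc1OC`, gives 4500 nM
- compound 2, `C=CCn1c(=O)/c(=C\c2ccccc2Cl)[nH]c(=O)/c1=C\c1ccccc1OC`, gives 4200 nM
- compound 3, `C=CCn1c(=O)/c(=C\c2cccc(Cl)c2Cl)[nH]c(=O)/c1=C\c1ccccc1OC`, gives 2000 nM

Compound 3 holds the lowest number of the three in this assay, its nearest neighbour being compound 2 and the furthest compound 1, both beyond the scatter. The measured steps show that moving the single chloro, a 1.1-fold lower number from compound 1 to compound 2 (0.03 log units; within the scatter), lies within the scatter, whereas adding a second chloro on the aromatic carbon, a 2.3-fold lower number from compound 1 to compound 3 (0.35 log units; beyond the scatter) and a 2.1-fold lower number from compound 2 to compound 3 (0.32 log units; beyond the scatter), brings a modest gain each time.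

Compound 4, `C=CCn1c(=O)/c(=C\c2cc(Br)ccc2F)[nH]c(=O)/c1=C\c1ccccc1OC`, differs from compound 3 by the change (5-bromo-2-fluorophenyl in place of 2,3-dichlorophenyl on a double-bonded chain carbon bound to an aromatic carbon). Among the measured compounds shown here, no measured step exchanges one halogen pair for another, so the steps above bear on it only loosely: they suggest that a second halogen helps modestly, but say nothing about bromine or fluorine. The expectation for compound 4 is therefore a step of a 1.5-fold higher number from compound 3 to compound 4 (0.18 log units; within the scatter), a small loss against compound 3 in this assay, probably within or near the scatter. Compound 4 is estimated at 3000 nM, with a range from 1200 nM to 8000 nM.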

Compound 4, half-maximal inhibitory concentration: 17400 nM
Compound 4: the middle estimate sits 5.8-fold (0.76 log units) below what was measured; measured number above the stated range.
By their numbers in this assay, from the lowest: compound 3; then compounds 2 and 1 (each within the scatter of the next); then compound 4.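

In this assay the aryl group on a double-bonded chain carbon bound to an aromatic carbon proves far more sensitive than the single-chloro and dichloro compounds had suggested: exchanging 2,3-dichlorophenyl for 5-bromo-2-fluorophenyl gives an 8.7-fold higher number from compound 3 to compound 4 (0.94 log units; beyond the scatter) even though both groups count the same number of heavy atoms and neither has a hydrogen-bond donor or acceptor. The 5-bromo-2-fluorophenyl group also falls behind each group bearing one chloro, with a 4.1-fold higher number from compound 2 to compound 4 (0.62 log units; beyond the scatter) and a 3.9-fold higher number from compound 1 to compound 4 (0.59 log units; beyond the scatter), so two halogens on this ring do not by themselves give the lower number, and compound 4 goes against the modest gain seen with compound 3. No measurement is available here that would account for this loss.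

Compound 3 and compound 4 differ both in the identity of their halogens and in the placement of those halogens. The compounds shown do not separate these two changes. They also leave open how this position would respond to a phenyl ring carrying an amine or a carboxylic acid instead of halogens.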